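A Nitro Group Added to the Ethoxy Compound

The compounds below may be only part of what the source reports. "The series", "measured", "known", "first", "only" and "open" are said of these compounds alone.

Compound 3 `CCOc1ccc2c(c1)OC(c1ccccc1)C(c1ccccc1)C2=O` gives 877000 nM in a functional assay (a higher number here means that more compound is needed for the effect, a lower number that less compound is needed), the higher of the two plain numbers shown; compound 1 `COc1ccc2c(c1)OC(c1cccc([N+](=O)[O-])c1)C(c1ccccc1)C2=O` gives 130000 nM, a gap beyond the scatter. Compound 2 `COc1ccc2c(c1)OC(c1ccc([N+](=O)[O-])cc1)C(c1ccccc1)C2=O` reaches only a limit in this assay, > 2500000 nM. That value of compound 2 is the limit of > 2500000 nM in this assay, at which 1 of the 3 values shown sits. Going by the values given here, the only measured step, an at least 19-fold higher number from compound 1 to compound 2 (1.28 log units; beyond the scatter), concerns the position of the nitro group rather than its addition, so it bears only loosely on the present change. Compound 4 `CCOc1ccc2c(c1)OC(c1cccc([N+](=O)[O-])c1)C(c1ccccc1)C2=O` differs from compound 3 by nitro in place of hydrogen on an aromatic carbon. Compounds 1 and 3 differ in two places, and their values show the nitro-bearing one with the lower number. Compound 4 is expected to need less compound, a step of a 2.9-fold lower number from compound 3 to compound 4 (0.47 log units; beyond the scatter). Compound 4 is estimated at 300000 nM, within a range from 100000 nM to 900000 nM.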

Compound 4, half-maximal effective concentration: 193000 nM
Compound 4: middle estimate off by 1.6-fold (0.19 log units), on the high side; measured number inside the range.
By their numbers in this assay, from the lowest: compounds 1 and 4 (each within the scatter of the next); then compound 3. At a limit, above all of these: compound 2.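

In this assay, going by these compounds alone, the nitro group now has a measured step of its own, a 4.5-fold lower number from compound 3 to compound 4 (0.66 log units; beyond the scatter), so phenyl to 3-nitrophenyl counts on the ethoxy compound, where the earlier compounds compared only nitro positions. Methyl in place of hydrogen on the chain bound to the oxygen leaves no readable difference, a 1.5-fold higher number from compound 1 to compound 4 (0.17 log units; within the scatter). Nothing measured here accounts for the nitro step.

As far as these compounds go, whether an amine or a carboxylic acid on the same aromatic carbon would give a similar step stays open. So does whether a longer chain than ethoxy would leave the number unchanged.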